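Swapping a para substituent on a benzamide ring

A few compounds are considered here, and "the series" means these few. Any claim that something is new, unique, unknown or untested is made for them only; others in the source may bear on it.

Of the compounds shown here, three of one series have been measured in an assay on isolated protein for inhibition of Rho-associated protein kinase 1 (Homo sapiens), read by scintillation counting, radiometric assay and 33P incorporation, with a stated time of 40 min, in the presence of a further agent that is not named here; on this read-out lower numbers stand for stronger inhibition and higher numbers for weaker inhibition. Compound 1, `Cc1c(OCC(=O)Nc2cccc(NC(=O)c3ccc(N(C)C)cc3)c2)ccc2c(=O)ccoc12`, reaches only the assay limit of > 10000 nM, which is a limit and not a number. Compound 2, `Cc1ccc(C(=O)Nc2cccc(NC(=O)COc3ccc4c(=O)ccoc4c3)c2)cc1`, gives 183 nM in this assay. Compound 3, `O=C(COc1ccc2c(=O)ccoc2c1)Nc1cccc(NC(=O)c2ccc(F)cc2)c1`, gives 129 nM in this assay, and its value sits within the scatter of that of compound 2, so the two cannot be told apart. Compound 1 stands apart from both. For the measured compounds named here, the single step measured so far is a 1.4-fold lower number from compound 2 to compound 3 (0.15 log units; within the scatter), a change that left the number essentially where it was.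

Compound 4, `O=C(COc1ccc2c(=O)ccoc2c1)Nc1cccc(NC(=O)c2ccc([N+](=O)[O-])cc2)c1`, is the next one to be measured. It differs from compound 3 by nitro in place of fluoro on an aromatic carbon. Going by the values given here, the one measured step at that same position was within the scatter, and no step to a nitro group has been measured, so the expectation for compound 4 leans on that single small step. Compound 4 is expected to give about 200 nM in this assay, within a range of 60 nM to 800 nM. The step this estimate implies is a 1.6-fold higher number from compound 3 to compound 4 (0.19 log units; within the scatter), expected to be no larger than the scatter, with a wider range than usual because a nitro group is new to the series.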

Compound 4, half-maximal inhibitory concentration: 67 nM
Compound 4: middle estimate off by 3.0-fold (0.47 log units), on the high side; the range from low to high includes it.
By their numbers in this assay, from the lowest: compounds 4, 3 and 2 (each within the scatter of the next, the first and the last beyond it). At a limit, above all of these: compound 1.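

For the compounds shown here, the nitro group gives the first step at this position that clears the scatter: a 2.7-fold lower number from compound 2 to compound 4 (0.44 log units; beyond the scatter) shows that the group placed here can measurably shift the number in this assay. Against fluoro the picture is different, with a 1.9-fold lower number from compound 3 to compound 4 (0.28 log units; within the scatter) leaving those two groups indistinguishable, so only the comparison with methyl separates anything. This closeness holds even though nitro brings 3 heavy atoms and 2 hydrogen-bond acceptors where fluoro brings a single atom and no acceptor, which means that these added atoms and acceptors did not push the number beyond the scatter in either direction.

Going by these compounds, whether an amine, a carboxylic acid or a nitrile in the same place would give a number like these or a very different one stays open, as does whether the nitro group would behave the same way on the core of compound 1. No measurement shown here speaks to which feature of the nitro group lies behind its step from methyl.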